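The source may report more compounds than this note shows. Statements on the series, on what has been measured and on what is new or still open speak of the compounds shown alone.

In a functional assay on A2780 cells (Homo sapiens) for antiproliferative activity, read by CellTiter-Glo, with a stated time of 4 days (on this read-out lower numbers stand for stronger inhibition and higher numbers for weaker inhibition), compound 1 (`C[C@H](NC(=O)[C@@H]1CCCN1C)c1ccc(NC(=O)[C@H]2C[C@@H]2c2cccnc2)cc1`) gives 1 nM and compound 2 (`C[C@H](NC(=O)c1ccc(F)cc1)c1ccc(NC(=O)[C@H]2C[C@@H]2c2cccnc2)cc1`) gives 2 nM, so compound 2 stands within the scatter of compound 1. Compound 3 (`C[C@H](NC(=O)c1ccc(C#N)cc1)c1ccc(NC(=O)[C@H]2C[C@@H]2c2cccnc2)cc1`) carries cyano in place of fluoro on an aromatic carbon, para to a large group (cyano in place of fluoro on an aromatic carbon). Within the data shown here, the only measured step puts 4-fluorophenyl in place of 1-methylpyrrolidin-2-yl on a carbonyl carbon (a 2.0-fold higher number from compound 1 to compound 2 (0.30 log units; within the scatter)). It stays within the scatter but does not test this exchange, so no change beyond the scatter is expected in this assay. The expected change (a 1.5-fold higher number from compound 2 to compound 3 (0.18 log units; within the scatter)) is correspondingly small. Compound 3 is estimated at 3 nM (range 1 nM to 8 nM) in this read-out.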

Compound 3, half-maximal inhibitory concentration in the A2780 assay: 4 nM
The estimate for compound 3 lay 1.3-fold (0.12 log units) below the measured number; low and high end bracket the measured number.
By their numbers in the A2780 assay, from the lowest: compounds 1, 2 and 3 (each within the scatter of the next, the first and the last beyond it).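

In the A2780 assay, cyano in place of fluoro on an aromatic carbon, para to a large group, gives a 2.0-fold higher number from compound 2 to compound 3 (0.30 log units; within the scatter), so this exchange leaves the number within the scatter, whereas the change on the carbonyl carbon gives a 4.0-fold higher number from compound 1 to compound 3 (0.60 log units; beyond the scatter), which lies beyond it. In a physicochemical assay for solubility, at pH 6.8 (a higher number here means a more soluble compound, a lower number a less soluble compound), compound 2 gives 6000 nM and compound 3 gives 175000 nM, so the same exchange of fluoro for cyano separates the two compounds widely: the measured solubility of compound 2, 6000 nM, and of compound 3, 175000 nM, a 29-fold higher number (1.46 log units; beyond the scatter). The compounds shown leave open whether an amine or a methoxy group on this aromatic carbon would hold the number in the A2780 assay and how it would read in the physicochemical assay.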